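A (4-Methylbenzyl)sulfanyl Group on an Inactive Compound

This account rests on a few compounds, and the source may have more. Where it says the series, first, only, none or still open, it means among the compounds named here.

In a functional assay on HepG2 cells (Homo sapiens) for inhibition, read by MTT assay, with a stated time of 48 h (a lower number here means a stronger inhibitor, a higher number a weaker inhibitor), compound 1 (`COc1ccc(-n2c(SC)nnc2-c2cc(OC)c(OC)c(OC)c2)cc1`) gives > 60000 nM as a limit and not a number. Compound 2 (`COc1ccc(NC(=O)CSc2nnc(-c3cc(OC)c(OC)c(OC)c3)n2-c2ccc(OC)cc2)cc1`) gives > 60000 nM as a limit too. Compound 3 (`COc1cc(-c2nnc(SC)n2-c2ccc(N(C)C)cc2)cc(OC)c1OC`) also stands only at a limit of > 60000 nM and has no number of its own. Compound 4 (`COc1cc(-c2nnc(SCc3ccc(C)cc3)n2-c2ccc(N(C)C)cc2)cc(OC)c1OC`) differs from it by 4-methylphenyl in place of hydrogen on a saturated chain carbon bound to a sulfur and so turns methylsulfanyl into (4-methylbenzyl)sulfanyl. For the measured compounds named here, two measured steps bear on this change. One is a step that the two limits leave unreadable from compound 1 to compound 2 with a substituent on the same saturated chain carbon, and the other is a step that the two limits leave unreadable from compound 1 to compound 3 with the dimethylamino group of compound 3. Neither gives a size, so only a slight move toward stronger inhibition is expected. The estimated change is an at least 1.2-fold lower number from compound 3 to compound 4 (0.07 log units; that floor lies within the scatter) and it may well stay unreadable. For compound 4 the expected value in this assay is 50000 nM within an estimated range of 15000 nM to 100000 nM and a further limit is quite likely.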

Compound 4, half-maximal inhibitory concentration: > 60000 nM
Compound 4: only a limit was reported; the forecaster's own chance of this, stated with the estimate: 70%; middle value at least 1.2-fold (0.07 log units) from the limit.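

For the compounds shown here, compound 3 and compound 4 both stand only at a limit in this assay, so no step between them can be read. The compounds shown leave open how strongly any of them inhibits, as all rest on one limit: the limit of > 60000 nM in this assay, at which 4 of the 4 values shown sit.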